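Compound 2 to compound 4: acetamido out, chloro in

This account rests on a few compounds, and the source may have more. Where it says the series, first, only, none or still open, it means among the compounds named here.

Measured so far in an ADME assay on MCF-10A cells (Homo sapiens) for cytotoxicity, read by WST assay, with a stated time of 48 h (a higher number here means a weaker inhibitor, a lower number a stronger inhibitor), one limit per line:
- compound 1 (`O=C(NNC(=S)Nc1ccc([N+](=O)[O-])cc1)c1ccncc1`) has the limit > 300000 nM in this read-out
- compound 2 (`CC(=O)Nc1ccc(NC(=S)NNC(=O)c2ccncc2)cc1`) has the limit > 300000 nM in this read-out
- compound 3 (`O=C(NNC(=S)Nc1cccc(Cl)c1)c1ccncc1`) has the limit > 300000 nM in this read-out

Compound 2 stands at the limit of > 300000 nM in this assay, at which 3 of the 3 values shown sit, and no order among the three compounds can be read. The next change puts chloro in place of acetamido on an aromatic carbon, para to a large group, and gives compound 4 (`O=C(NNC(=S)Nc1ccc(Cl)cc1)c1ccncc1`), counted as follows (chloro in place of acetamido on an aromatic carbon).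

Within the data shown here, the one measured step that touches the acetamido group is a step that the two limits leave unreadable from compound 1 to compound 2 and it offers no size to carry over. The nearest guide is compound 3, which also carries chloro and sits at the limit > 300000 nM in this read-out. On that basis no step beyond the scatter is expected in this assay and a further limit is the likely report. The expected size is a step that the limit leaves unreadable from compound 2 to compound 4 and it is read against a limit, not a number. For compound 4 the estimate is 350000 nM with an expected range from 150000 nM to 800000 nM as its ends.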

Compound 4, half-maximal inhibitory concentration: > 300000 nM
Compound 4 gave a limit, no number (the forecaster's own chance of this, stated with the estimate: 80%); the middle value is on the limit's open side.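

In this assay compound 4 gives > 300000 nM, which is a limit and not a number. No step can be read between compound 4 and either compound 1 or compound 2, since all share one limit: the limit of > 300000 nM in this assay, at which 4 of the 4 values shown sit.

The compounds shown leave open how the nitro, acetamido and chloro groups rank, and whether any change to the shared core would give a number in this assay.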